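Methoxy step repeated across two pairs sitting at the limit

The source may report more compounds than this note shows. Statements on the series, on what has been measured and on what is new or still open speak of the compounds shown alone.

Compound 2 `[SeH]c1nc(NCc2ccccc2)c2ccccc2n1` is the smallest member of the set. In a functional assay on HT-29 cells (Homo sapiens) for cytotoxicity, read by MTT assay, with a stated time of 72 h (a lower number here means a stronger inhibitor of growth, a higher number a weaker inhibitor of growth), compound 2 gives only a limit of the assay, > 100000 nM being the reading. Compound 1 `COc1ccc(CNc2nc([SeH])nc3ccccc23)cc1` carries methoxy in place of hydrogen on an aromatic carbon on the same core, and in this assay compound 1 likewise returns only a limit, > 100000 nM being recorded. Compound 3 `CSc1nc(NCc2ccccc2)c2ccccc2n1` differs from compound 2 in the core by a group of 2 heavy atoms (1 carbon, 1 sulfur; no ring) in place of one selenium atom, on an aromatic carbon and in this assay compound 3 too stops at a limit, > 100000 nM being the reading. For the measured compounds named here, the steps are therefore a step that the two limits leave unreadable from compound 2 to compound 1 and a step that the two limits leave unreadable from compound 2 to compound 3 and the one fact shared by all three is the limit of > 100000 nM in this assay, at which 3 of the 3 values shown sit, for every value so far.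

Compound 4 `COc1ccc(CNc2nc(SC)nc3ccccc23)cc1` is not yet measured. It stands to compound 3 as compound 1 stands to compound 2, since methoxy in place of hydrogen on an aromatic carbon is the same change at a place described in identical words. The step is expected to be a step that the limit leaves unreadable from compound 3 to compound 4 in size, an expectation that rests on compound 2 and compound 1 being unreadable because the limit of > 100000 nM in this assay, at which 3 of the 3 values shown sit, holds for both. Compound 4 is estimated at 150000 nM with a range from 50000 nM to 500000 nM and most probably another limit.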

Compound 4, concentration for total growth inhibition: > 100000 nM
Compound 4 gave a limit, no number (the forecaster's own chance of this, stated with the estimate: 85%); the middle value does not contradict the limit.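

Neither the step from compound 3 to compound 4 nor the step from compound 1 to compound 4 can be read, because in this assay compound 4 also returns only a limit: the limit of > 100000 nM in this assay, at which 4 of the 4 values shown sit.

The compounds shown leave open whether methoxy or the replacement of selenium changes growth inhibition at all, and at what concentration any of the four would reach total growth inhibition.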